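From benzyloxy to bromo: a step behind a limit

The source may hold more compounds than are shown below. What is called first, only, known or untested is meant among the compounds shown, and "the series" means these compounds.

Values from an ADME assay on BJ cells (Homo sapiens) for cytotoxicity, read by luminescence, with a stated time of 72 h (on this read-out lower numbers stand for an effect already at smaller amounts and higher numbers for an effect only at larger amounts of compound), follow
Compound 1 `C=Cc1cccc(-c2[nH]c3cc(OC)ccc3c(=O)c2C(=O)OCC)c1` gives > 21500 nM
Compound 2 `CCOC(=O)c1c(-c2cccc(-c3ccccc3)c2)[nH]c2cc(OC)ccc2c1=O` gives > 21500 nM
Compound 3 `CCOC(=O)c1c(-c2cccc(OCc3ccccc3)c2)[nH]c2cc(OC)ccc2c1=O` gives > 21500 nM

Compound 3 stands at > 21500 nM in this assay and this is a limit of the assay, not a number. All the measured compounds share this position (the limit of > 21500 nM in this assay, at which 3 of the 3 values shown sit). Compound 4 `CCOC(=O)c1c(-c2cccc(Br)c2)[nH]c2cc(OC)ccc2c1=O` differs from compound 3 by bromo in place of benzyloxy on an aromatic carbon. Within the data shown here, two measured steps bear on this change (a step that the two limits leave unreadable from compound 1 to compound 3; a step that the two limits leave unreadable from compound 2 to compound 3) and neither has a readable size. No step beyond the scatter is therefore expected in this assay and no direction can be expected either, so the estimated step is a step that the limit leaves unreadable from compound 3 to compound 4 and nothing more. Compound 4 is expected at 30000 nM with an estimated range of 15000 nM to 60000 nM.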

Compound 4, half-maximal effective concentration: > 21500 nM
Compound 4 ended at the assay's limit; the forecaster's own chance of this, stated with the estimate: 85%; the middle value is on the limit's open side.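

Compound 4 gives > 21500 nM, a limit and not a number, so its steps from compound 1, compound 2 and compound 3 cannot be read. The compounds shown leave open whether vinyl, phenyl, benzyloxy or bromo changes the value at all.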